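The source may report more compounds than this note shows. Statements on the series, on what has been measured and on what is new or still open speak of the compounds shown alone.

Compound 1 `COC(=O)[C@@]1(CC=C(C)C)C[C@H](CC=C(C)C)C(C)(C)[C@H](C(=O)C(C)C)C1=O` gives > 10000 nM in a functional assay on SNU1 cells (Homo sapiens) for cytotoxicity, read by CellTiter-Glo, with a stated time of 5 days (a lower number here means a stronger inhibitor, a higher number a weaker inhibitor), a limit of the assay rather than a number.
Compound 2 `CC(C)=CC[C@@H]1C[C@H](CC=C(C)C)C(C)(C)[C@H](C(=O)C(C)C)C1=O` gives > 10000 nM in this assay, again a limit and not a number.

Compound 2 thus stands at the assay's limit, where both shown values sit (the limit of > 10000 nM in this assay, at which 2 of the 2 values shown sit). Compound 3 `COC(=O)[C@]1(CC=C(C)C)C[C@H](CC=C(C)C)C(C)(C)[C@H](C(=O)C(C)C)C1=O` differs from compound 2 by methoxycarbonyl in place of hydrogen on a saturated ring carbon. Within the data shown here, no step between measured compounds shows how such a change shifts the value in this assay; since both values rest at the limit (the limit of > 10000 nM in this assay, at which 2 of the 2 values shown sit), no movement beyond the scatter is expected, the expected step from compound 2 to compound 3 being a step that the limit leaves unreadable from compound 2 to compound 3. Compound 3 is estimated at 15000 nM, within 7000 nM to 40000 nM, most likely reported again only as a limit.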

Compound 3, half-maximal inhibitory concentration: > 10000 nM
Compound 3: only a limit was reported (the forecaster's own chance of this, stated with the estimate: 85%); the middle value is on the limit's open side.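

In this assay compound 3 gives > 10000 nM, again a limit and not a number. Among these compounds, no step from compound 1 or compound 2 to compound 3 can be read. As far as these compounds go, whether methoxycarbonyl or the configuration as drawn changes the value at all stays open.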